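Moving the chlorine on the oxazole-linked phenyl ring

The source may hold more compounds than are shown below. What is called first, only, known or untested is meant among the compounds shown, and "the series" means these compounds.

Measured compounds:
Compound 1 `Cc1csc(C(=O)N[C@H]2CN(S(=O)(=O)c3ccccc3)C[C@@H]2C(=O)N[C@H]2CCCNC2)n1`: 63%
Compound 2 `O=C(N[C@H]1CN(S(=O)(=O)c2ccccc2)C[C@@H]1C(=O)N[C@H]1CCCNC1)c1cc(C2CC2)n[nH]1`: 81%
Compound 3 `O=C(N[C@H]1CN(S(=O)(=O)c2ccccc2)C[C@@H]1C(=O)N[C@H]1CCCNC1)c1cc(-c2ccc(Cl)cc2)on1`: 91%

Three compounds share one core and differ only in the ring attached to a carbonyl carbon. In a functional assay on HEK293 cells for agonist activity at growth hormone secretagogue receptor type 1 (Homo sapiens), read by HTRF and inositol phosphate accumulation, with a stated time of 90 min, in the presence of a further agent that is not named here (on this read-out higher numbers stand for larger maximal responses and lower numbers for smaller maximal responses), compound 1 gives 63%, and the change to compound 2 brought a number 18 percentage points higher from compound 1 to compound 2 (beyond the scatter). Among the measured compounds shown here, compound 3 gives the highest of the three numbers, but the step of a number 10 percentage points higher from compound 2 to compound 3 (within the scatter) lies within the scatter, so compound 2 and compound 3 cannot be put in order; only the step of a number 28 percentage points higher from compound 1 to compound 3 (beyond the scatter) is beyond it.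

Compound 4 `O=C(N[C@H]1CN(S(=O)(=O)c2ccccc2)C[C@@H]1C(=O)N[C@H]1CCCNC1)c1cc(-c2ccccc2Cl)on1` differs from compound 3 in one place: 2-chlorophenyl in place of 4-chlorophenyl on an aromatic carbon. For the measured compounds named here, none of the measured steps changes this part of the molecule; each one swaps the whole ring on the carbonyl carbon, so there is no direct precedent. With both rings the same size and with the same atoms, a small step is expected, not beyond the scatter. Compound 4 is expected to give 84%, between 66% and 100%. That estimate means a step of a number 7 percentage points lower from compound 3 to compound 4 (within the scatter).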

Compound 4, largest response reached (Emax), in percent of the reference or control that the assay uses: 98%
The estimate for compound 4 lay 14 percentage points below the measured number; the range from low to high includes it.
By their numbers in this assay, from the lowest: compound 1; then compounds 2, 3 and 4 (each within the scatter of the next, the first and the last beyond it).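

Moving the chlorine from 4-chlorophenyl to 2-chlorophenyl keeps the same atoms and gives, in this assay, a number 7 percentage points higher from compound 3 to compound 4 (within the scatter), so the place of the chlorine on this phenyl ring makes no readable difference. Against the smaller rings, the 2-chlorophenyl compound gives a number 17 percentage points higher from compound 2 to compound 4 (beyond the scatter) and a number 35 percentage points higher from compound 1 to compound 4 (beyond the scatter); the first of these steps clears the scatter, which the matching step with 4-chlorophenyl did not, yet compound 3 and compound 4 still cannot be put in order. Nothing available here bears on why the response holds when the chlorine moves.

The compounds shown leave open whether the chlorine matters at all, which a plain phenyl ring would test. They also leave open what an amine or a carboxylic acid in its place would give.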